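The compounds below may be only part of what the source reports. "The series", "measured", "known", "first", "only" and "open" are said of these compounds alone.

Compound 1, `O=c1sc2ccccc2n1CCCCCN1CCCCCC1`, in an assay on cell membranes for displacement of a labelled ligand from Sigma non-opioid intracellular receptor 1 (Rattus norvegicus) (a lower number here means a stronger inhibitor, a higher number a weaker inhibitor), gives 7 nM.
Compound 2, `CCC(=O)c1ccc2c(c1)sc(=O)n2CCCN1CCCCCC1`, gives 3.7 nM.
Compound 3, `CCC(=O)c1ccc2c(c1)sc(=O)n2CCCCN1CCCCCC1`, gives 10.3 nM.

Among these three, compound 3 stands at the highest number in this assay; compound 1 lies nearest to it, within the usual scatter, while compound 2 lies below it by more than the scatter. Compound 4, `CCC(=O)c1ccc2c(c1)sc(=O)n2CCCCCN1CCCCCC1`, differs from compound 3 by (azepan-1-yl)methyl in place of azepan-1-yl on a saturated chain carbon, four bonds along the chain from an aromatic nitrogen. Going by the values given here, the one measured step that resembles this change is the lengthening of the same chain going from compound 2 to compound 3, a 2.8-fold higher number from compound 2 to compound 3 (0.44 log units; beyond the scatter), a modest rise. The longer chain of compound 4 is shared with a compound that has a different core, and that compound, compound 1, gives 7 nM, a number close to that of compound 3. A further lengthening is therefore expected to shift the number only slightly, most likely upward, and probably not beyond the scatter. The estimate for compound 4 in this assay is 13 nM, with a range of 5 nM to 35 nM, meaning an expected step of a 1.3-fold higher number from compound 3 to compound 4 (0.10 log units; within the scatter).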

Compound 4, inhibition constant: 12.2 nM
Estimate against measurement, compound 4: 1.1-fold (0.03 log units) above; measured number inside the range.
By their numbers in this assay, from the lowest: compounds 2, 1, 3 and 4 (each within the scatter of the next, the first and the last beyond it).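

In this assay, placing (azepan-1-yl)methyl in place of azepan-1-yl at this point on the chain gives a 1.2-fold higher number from compound 3 to compound 4 (0.07 log units; within the scatter) and stays within the scatter, unlike the earlier lengthening (a 2.8-fold higher number from compound 2 to compound 3 (0.44 log units; beyond the scatter)). Going by these compounds alone, the result also gives the first reading of propanoyl in place of hydrogen on an aromatic carbon (a 1.7-fold higher number from compound 1 to compound 4 (0.24 log units; within the scatter)), and at this chain length that change also stays within the scatter. No measurement here accounts for either step.

From the compounds shown here alone, a chain longer than that of compound 4 remains open, as does a piperidin-1-yl or morpholin-4-yl ring in place of azepan-1-yl. Also open, going by these compounds, is whether acetyl or butanoyl in place of propanoyl would read differently, or whether removing propanoyl would matter on the shorter chain of compound 2.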